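Chain length in the sulfonyl series: compound 3 to compound 4

The compounds below may be only part of what the source reports. "The series", "measured", "known", "first", "only" and "open" are said of these compounds alone.

Measured compounds in a functional assay, read by fluorescence and spectrophotometry, with a stated time of 1 h; on this read-out higher numbers stand for an effect only at larger amounts of compound and lower numbers for an effect already at smaller amounts:
compound 1 `CCCCCCCS(=O)(=O)/C=C/c1ccc(O)c(O)c1`: 7100 nM
compound 2 `O=S(=O)(/C=C/c1ccc(O)c(O)c1)CCCc1ccccc1`: 11500 nM
compound 3 `CCCCCCCCCCCS(=O)(=O)/C=C/c1ccc(O)c(O)c1`: 11400 nM

Compound 3 gives the second highest of the three numbers; its nearest neighbour is compound 2 and its furthest compound 1, and both gaps sit within the scatter. The unmeasured compound 4 `CCCCCCCCCS(=O)(=O)/C=C/c1ccc(O)c(O)c1` differs from compound 3 as follows: hydrogen in place of ethyl on a saturated chain carbon, nine bonds along the chain from a sulfonyl sulfur. Among the compounds with values here, two measured steps bear on this change. Lengthening the chain gave a 1.6-fold higher number from compound 1 to compound 3 (0.21 log units; within the scatter), and exchanging a phenyl for a longer alkyl end gave a 1.0-fold lower number from compound 2 to compound 3 (0.00 log units; within the scatter); neither moved the number beyond the scatter. Removing an ethyl from the far end of the chain is a smaller version of these same chain changes, so no step beyond the scatter is expected for compound 4 in this assay. The estimated step is a 1.1-fold lower number from compound 3 to compound 4 (0.06 log units; within the scatter). Compound 4 is therefore expected to give about 10000 nM, with a likely range from 5000 nM to 20000 nM, resting on the flat response seen from compound 1 to compound 3.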

Compound 4, half-maximal effective concentration: 7700 nM
The estimate for compound 4 lay 1.3-fold (0.11 log units) above the measured number, and the stated range covers the measured number.
By their numbers in this assay, from the lowest: compounds 1, 4, 3 and 2 (each within the scatter of the next).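

Removing ethyl nine bonds along the chain from a sulfonyl sulfur does not move the number in this assay beyond the scatter, the step being a 1.5-fold lower number from compound 3 to compound 4 (0.17 log units; within the scatter) in this series. The other comparisons give the same reading, with a 1.1-fold higher number from compound 1 to compound 4 (0.04 log units; within the scatter) on the alkyl side and a 1.5-fold lower number from compound 2 to compound 4 (0.17 log units; within the scatter) against the phenyl-ended chain, so all four compounds now sit within the scatter of one another and this part of the chain shows no dependence on length or on the phenyl end in this assay. No measurement on hand accounts for this flat response.

Still open, as far as these compounds go, is whether a much shorter chain, a longer chain, or a chain ending in an amine or a carboxylic acid would move the number beyond the scatter. Also open, from the compounds shown here alone, is whether a change on the shared core, rather than in the chain, would do so.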